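A Cytotoxicity Step from a Bromophenyl to a Cyanophenyl Group

A few compounds are considered here, and "the series" means these few. Any claim that something is new, unique, unknown or untested is made for them only; others in the source may bear on it.

Compound 1 is `O=c1ccoc2cc(OCc3cn(Cc4ccccc4Br)nn3)ccc12`. In an ADME assay on L02 cells (Homo sapiens) for cytotoxicity, read by MTT assay, with a stated time of 48 h (on this read-out higher numbers stand for weaker inhibition and lower numbers for stronger inhibition), compound 1 gives > 300000 nM, which is a limit of the assay rather than a number. Compound 2, `O=c1ccoc2cc(OCc3cn(Cc4ccc(Cl)cc4)nn3)ccc12`, carries a 4-chlorophenyl in place of the 2-bromophenyl on a saturated chain carbon bound to an aromatic nitrogen. In this assay compound 2 gives > 300000 nM, which is also a limit. The step that the two limits leave unreadable from compound 1 to compound 2 cannot be read because of the limit of > 300000 nM in this assay, at which 2 of the 2 values shown sit. The new compound 3 is `N#Cc1cccc(Cn2cc(COc3ccc4c(=O)ccoc4c3)nn2)c1`, and it differs from compound 1 as 3-cyanophenyl in place of 2-bromophenyl on a saturated chain carbon bound to an aromatic nitrogen. Within the data shown here, the only measured step that bears on exchanging the group on this chain carbon is unreadable, so it gives no sign of movement in this assay. The expectation is that compound 3 also stays at the limit, with an estimated step of a number no higher from compound 1 to compound 3 (the limit leaves the size open). The estimate for compound 3 is 300000 nM, within 100000 nM to 1000000 nM.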

Compound 3, half-maximal inhibitory concentration: > 300000 nM
Compound 3 was reported as a limit (the forecaster's own chance of this, stated with the estimate: 80%); the middle value lies on the limit itself.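

Among these compounds, no step between compound 1, compound 2 and compound 3 can be read in this assay, because each result is a limit of the assay rather than a number: the limit of > 300000 nM in this assay, at which 3 of the 3 values shown sit. The compounds shown leave open how their true values compare and whether any group on this chain carbon would bring a value within the assay's range.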